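The source may hold more compounds than are shown below. What is called first, only, known or untested is meant among the compounds shown, and "the series" means these compounds.

Measured compounds: compound 1 `CC(O)(CSc1ccc(Cl)cc1)c1nc(-c2ccccc2)no1` with 70700 nM; compound 2 `CC(O)(CSc1ccc(F)cc1)c1nc(-c2ccccc2)no1` with > 100000 nM; compound 3 `CC(O)(CS(=O)(=O)c1ccc(F)cc1)c1nc(-c2ccc(F)c(Cl)c2)no1` with > 100000 nM.

In a functional assay on DU-145 cells (Homo sapiens) for cytotoxicity, read by MTT assay (on this read-out lower numbers stand for stronger inhibition and higher numbers for weaker inhibition), compound 1 gives 70700 nM. Compound 2 gives only a limit of this assay, > 100000 nM. Compound 3 likewise gives only a limit, > 100000 nM; this is the limit of > 100000 nM in this assay, at which 2 of the 3 values shown sit. From compound 2 to compound 1 the change is chloro in place of fluoro on an aromatic carbon, and it produces an at least 1.4-fold lower number from compound 2 to compound 1 (0.15 log units; that floor lies within the scatter). Compound 4 `CC(O)(CS(=O)(=O)c1ccc(Cl)cc1)c1nc(-c2ccc(F)c(Cl)c2)no1` differs from compound 3 by chloro in place of fluoro on an aromatic carbon, the same change at the same place. The difference between the two cores is not broken down here. For compound 4 the expected step is an at least 1.1-fold lower number from compound 3 to compound 4 (0.07 log units; that floor lies within the scatter). That expectation rests on the step of an at least 1.4-fold lower number from compound 2 to compound 1 (0.15 log units; that floor lies within the scatter). It also rests on compound 3 giving only the limit > 100000 nM. Compound 4 is therefore expected to give about 85000 nM, between 35000 nM and 200000 nM.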

Compound 4, half-maximal inhibitory concentration: 35500 nM
The estimate for compound 4 lay 2.4-fold (0.38 log units) above the measured number; low and high end bracket the measured number.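

In this assay, going from 4-fluorophenyl to 4-chlorophenyl gives an at least 2.8-fold lower number from compound 3 to compound 4 (0.44 log units; beyond the scatter), so the change lowers the number on this core too, and here by more than the scatter. The starting points, compound 2 and compound 3, are limits of the assay and not numbers: the limit of > 100000 nM in this assay, at which 2 of the 4 values shown sit. The direction therefore carries from one core to the other, but this does not show that the size of the step carries too: the same change on two cores in this assay, an at least 1.4-fold lower number (0.15 log units; that floor lies within the scatter) from compound 2 to compound 1 and an at least 2.8-fold lower number (0.44 log units; beyond the scatter) from compound 3 to compound 4; the limit leaves it open whether they differ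

The compounds shown leave open how a bromo, a methoxy or an amine at that same place would read in this assay. They also leave open whether the change from fluoro to chloro would lower the number on a third core.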